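Shortening the chain further: what to expect of compound 3

The source may report more compounds than this note shows. Statements on the series, on what has been measured and on what is new or still open speak of the compounds shown alone.

Values in a functional assay on A549 cells (Homo sapiens) for antiproliferative activity, read by MTT assay, with a stated time of 72 h; on this read-out lower numbers stand for stronger inhibition and higher numbers for weaker inhibition:
- Compound 1 `CCCCCCCCCCNC[C@@H]1OC[C@H](N)[C@@H]1O`: 47800 nM
- Compound 2 `CCCCCCCCNC[C@@H]1OC[C@H](N)[C@@H]1O`: > 128000 nM (a limit of the assay, not a number)

Of these two compounds, only compound 1 has a true number. Compound 2 stands at the limit of > 128000 nM in this assay, at which 1 of the 2 values shown sits.

Compound 3 `CCCCCCCNC[C@@H]1OC[C@H](N)[C@@H]1O` is the next compound to be tested. It carries hydrogen in place of methyl on a saturated chain carbon, seven bonds along the chain from an amine nitrogen.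

Within the data shown here, one measured step bears on this change, and it also shortens the chain: an at least 2.6-fold higher number from compound 1 to compound 2 (0.42 log units; beyond the scatter). As far as these compounds go, its true size is unknown, since one end of it is a limit. With that single step as the guide, a further shortening is expected to move the number in this assay higher, towards weaker inhibition, or to leave it out of reach. A report of only a limit is therefore the likeliest result. The expected change is a step that the limit leaves unreadable from compound 2 to compound 3. For compound 3 the estimated value is 190000 nM, with an expected range of 128000 nM to 450000 nM.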

Compound 3, half-maximal inhibitory concentration: > 128000 nM
Compound 3: no number, only a limit; the forecaster's own chance of this, stated with the estimate: 85%; the middle value does not contradict the limit.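

In this assay, compound 3 gives > 128000 nM, which is a limit of the assay and not a number. Compared with the longer decyl-type chain of compound 1, the loss seen on the first shortening persists on going further, with an at least 2.6-fold higher number from compound 1 to compound 3 (0.42 log units; beyond the scatter), and the true size of this step is unknown, since one of its ends is a limit. Replacing methyl with hydrogen at this place gives a step from compound 2 that cannot be read, since both of its ends are limits, so this change neither restores a measurable number nor shows how much further activity falls, and the series now rests largely on its upper boundary: the limit of > 128000 nM in this assay, at which 2 of the 3 values shown sit.

The compounds shown therefore leave open whether compound 2 and compound 3 really differ, and they give only one true number from which to judge the effect of chain length. A longer chain than that of compound 1 would show whether the number in this assay keeps falling as the chain grows, while an added amine or carboxylic acid on the chain would show whether this read-out depends only on chain length.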